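The source may hold more compounds than are shown below. What is called first, only, known or untested is meant among the compounds shown, and "the series" means these compounds.

Measured compounds:
compound 1 `O=C(/C=C/c1ccccc1Br)NNC(=O)c1ccc2c(c1)OCCO2`, in a functional assay on cells (Cancer cell lines, Homo sapiens) for inhibition, read by MTT assay, with a stated time of 48 h (a higher number here means a weaker inhibitor, a lower number a stronger inhibitor), compound 1 gives 2110 nM
compound 2 `COc1ccccc1/C=C/C(=O)NNC(=O)c1ccc2c(c1)OCCO2`, in this assay compound 2 gives 8060 nM
compound 3 `O=C(/C=C/c1cccc(F)c1)NNC(=O)c1ccc2c(c1)OCCO2`, in this assay compound 3 gives 4110 nM

All three share the same core and differ only in the aryl group on the double-bonded chain. Compound 2 gives the highest number of the set: one step, a 3.8-fold higher number from compound 1 to compound 2 (0.58 log units; beyond the scatter), lies beyond the scatter, while the gap to compound 3, a 2.0-fold lower number from compound 2 to compound 3 (0.29 log units; within the scatter), does not leave the scatter.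

Compound 4 `COc1cccc(/C=C/C(=O)NNC(=O)c2ccc3c(c2)OCCO3)c1` is not yet measured. Its change from compound 2 is 3-methoxyphenyl in place of 2-methoxyphenyl on a double-bonded chain carbon bound to a double-bonded chain carbon.

The measured step that bears most directly on this is the move from compound 2 to compound 3, which also exchanges the 2-methoxyphenyl for a group on a different ring position and came out as a 2.0-fold lower number from compound 2 to compound 3 (0.29 log units; within the scatter). The comparison of compound 1 with compound 3, a 1.9-fold higher number from compound 1 to compound 3 (0.29 log units; within the scatter), likewise stays within the scatter. Nothing in the set tests a methoxy group at the new position, so the expectation for this assay is a small step, at most a slightly lower number, not clearly beyond the scatter: a 1.5-fold lower number from compound 2 to compound 4 (0.17 log units; within the scatter) is the expected step.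

Compound 4 is therefore estimated at 5500 nM, with a range of 2500 nM to 12000 nM.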

Compound 4, half-maximal inhibitory concentration: 170 nM
For compound 4 the middle estimate is 32-fold (1.51 log units) above the measured one; measured number outside the range, below it.
By their numbers in this assay, from the lowest: compound 4; then compounds 1, 3 and 2 (each within the scatter of the next, the first and the last beyond it).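

Moving the methoxy from 2-methoxyphenyl to 3-methoxyphenyl, on the same chain carbon and with the same atoms, gives in this assay the largest step in the series, a 47-fold lower number from compound 2 to compound 4 (1.68 log units; beyond the scatter), so the placing of this one group matters far more than the earlier aryl exchanges indicated. Compound 4 also stands clear of the other two aryl groups, with a 24-fold lower number from compound 3 to compound 4 (1.38 log units; beyond the scatter) and a 12-fold lower number from compound 1 to compound 4 (1.09 log units; beyond the scatter), so among these compounds the 3-fluorophenyl group does not reproduce the gain, and only the 3-methoxyphenyl group shows it. No measurement at hand accounts for the size of this step.

As far as these compounds go, whether the gain is specific to methoxy remains open: an ethoxy, hydroxy or amine group in that ring position would test this. From the compounds shown here alone, the effect of 4-methoxyphenyl on the same chain carbon is also open.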